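A few compounds are considered here, and "the series" means these few. Any claim that something is new, unique, unknown or untested is made for them only; others in the source may bear on it.

Two members of the series have so far been run in a functional assay, tested at 100 ug/mL; a higher number here means a stronger effect of the compound at the concentration tested, a lower number a weaker effect. Compound 1 `CN(C)c1ccc(C2C(C#N)=C(N)OC(c3c[nH]c4ccccc34)=C2C#N)cc1` gives 18.5%. Compound 2 `N#CC1=C(N)OC(c2c[nH]c3ccccc23)=C(C#N)C1c1ccccc1Cl` gives 10.4%. The step of a number 8.1 percentage points lower from compound 1 to compound 2 (within the scatter) is within the scatter, so compound 2 and compound 1 cannot be told apart on these numbers; compound 2 stands alongside compound 1 rather than apart from it.

Going by the values given here, compound 3 `N#CC1=C(N)OC(c2c[nH]c3ccccc23)=C(C#N)C1c1ccccc1` is the next member and has not yet been measured. hydrogen in place of chloro on an aromatic carbon The one measured step, a number 8.1 percentage points lower from compound 1 to compound 2 (within the scatter), exchanged a whole aryl group for another and so swept in more than the chloro alone; no step isolates the chloro by itself. That step is nevertheless the closest guide, and its size lay within the scatter. The expectation for this assay is therefore a step of no size beyond the scatter, in no settled direction, a number 1.6 percentage points higher from compound 2 to compound 3 (within the scatter). Compound 3 is estimated at 12%, with a range from 3% to 25%.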

Compound 3, a percentage reported as activity, at one concentration (the size of the read-out at that concentration, not a potency): 19.3%
The estimate for compound 3 lay 7.3 percentage points below the measured number, within the range that was stated.
By their numbers in this assay, from the lowest: compounds 2, 1 and 3 (each within the scatter of the next).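

Going by these compounds alone, compound 3, with its plain phenyl, is the first member to isolate the chloro: in this assay, hydrogen in place of chloro on an aromatic carbon, ortho to a large group, reads as a number 8.9 percentage points higher from compound 2 to compound 3 (within the scatter) and so stays inside the usual spread of repeats. It also isolates the dimethylamino group, where hydrogen in place of dimethylamino on an aromatic carbon reads as a number 0.8 percentage points higher from compound 1 to compound 3 (within the scatter) and this aryl group, in the three forms compared here, therefore gives no separable read-out in this assay. No supporting measurement on these compounds bears on this result.

From the compounds shown here alone, it remains open whether a carboxylic acid, a primary amine or a longer alkyl chain on this phenyl ring would give a step beyond the scatter, and whether chloro or dimethylamino would read the same at another place on the ring. Also open, going by these compounds, is whether a change to the shared core, rather than to this aryl group, would separate any member from the three compared here, since a read-out at a single concentration gives no potency to set them apart.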